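Swapping the amine on a cytotoxicity series

The source may report more compounds than this note shows. Statements on the series, on what has been measured and on what is new or still open speak of the compounds shown alone.

Compound 1 `CC1=NN(C(=O)c2ccc(C)cc2)C(c2cc(Br)cc(Br)c2O)C1` and compound 2 `CCNCC(=O)N1N=C(c2cc3ccccc3oc2=O)CC1c1ccccc1` were both tested in a functional assay on MGC-803 cells (Homo sapiens) for cytotoxicity, read by MTT assay, with a stated time of 48 h; on this read-out lower numbers stand for stronger inhibition and higher numbers for weaker inhibition. Compound 1 gives 56500 nM, while compound 2 gives 26600 nM, the lower of the two numbers, and the gap between them lies beyond the usual scatter. Compound 3 `NC(=O)C1CCN(CC(=O)N2N=C(c3cc4ccccc4oc3=O)CC2c2ccccc2)CC1` has not been measured; it differs from compound 2 by one change: 4-carbamoylpiperidin-1-yl in place of ethylamino on a saturated chain carbon bound to a carbonyl carbon. Going by the values given here, with no comparable step among the measured pair, only a small shift is expected, in either direction or none beyond the scatter. In this assay compound 3 is estimated at 20000 nM, between 7000 nM and 60000 nM, a step of a 1.3-fold lower number from compound 2 to compound 3 (0.12 log units; within the scatter).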

Compound 3, half-maximal inhibitory concentration: 21500 nM
The estimate for compound 3 lay 1.1-fold (0.03 log units) below the measured number; the range from low to high includes it.
By their numbers in this assay, from the lowest: compounds 3 and 2 (each within the scatter of the next); then compound 1.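

Replacing ethylamino with 4-carbamoylpiperidin-1-yl on a saturated chain carbon bound to a carbonyl carbon gives a 1.2-fold lower number from compound 2 to compound 3 (0.09 log units; within the scatter) in this assay. Going by these compounds alone, this position therefore accepts a larger group containing a six-membered non-aromatic ring with no change beyond the scatter, which the earlier compounds could not show. No measurements are available to explain this result.

From the compounds shown here alone, it remains open whether plain piperidin-1-yl or a carboxylic acid in place of the carbamoyl would give a similar number. It is also unknown whether any other amine here would shift the number beyond the scatter.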